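Swapping a cyclopropyl for a bulkier ring on an amide

The source may hold more compounds than are shown below. What is called first, only, known or untested is meant among the compounds shown, and "the series" means these compounds.

Measured compounds:
compound 1 `Cc1noc(C)c1-c1nn(Cc2ccc(C(=O)NC3CC3)cc2)c(=O)c2ccccc12`: > 100000 nM
compound 2 `Cc1noc(C)c1-c1nn(Cc2ccc(C(=O)NC3CC(C)(C)N([O])C(C)(C)C3)cc2)c(=O)c2ccccc12`: 83500 nM
compound 3 `Cn1cc(-c2nn(Cc3ccc(C(=O)NC4CC4)cc3)c(=O)c3ccccc23)cn1`: 40000 nM

In a functional assay on HeLa cells (Homo sapiens) for antiproliferative activity, read by MTT assay, with a stated time of 72 h (on this read-out higher numbers stand for weaker inhibition and lower numbers for stronger inhibition), compound 1 reaches only a limit of the assay, > 100000 nM, and not a number (the limit of > 100000 nM in this assay, at which 1 of the 3 values shown sits). Compound 2 differs from compound 1 by a group of 11 heavy atoms (9 carbon, 1 nitrogen, 1 oxygen; one six-membered non-aromatic ring with 1 hetero atom) in place of a group of 3 heavy atoms (3 carbon; one three-membered non-aromatic ring of carbon only), on an amide-type nitrogen, and this gave an at least 1.1-fold lower number from compound 1 to compound 2 (0.07 log units; that floor lies within the scatter). Compound 3 carries a different core, (1-methyl-1H-pyrazol-4-yl in place of 3,5-dimethyl-1,2-oxazol-4-yl on an aromatic carbon), and this gave an at least 2.5-fold lower number from compound 1 to compound 3 (0.39 log units; beyond the scatter).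

Compound 4 `Cn1cc(-c2nn(Cc3ccc(C(=O)NC4CC(C)(C)N([O])C(C)(C)C4)cc3)c(=O)c3ccccc23)cn1` is not yet measured. It differs from compound 3 by a group of 11 heavy atoms (9 carbon, 1 nitrogen, 1 oxygen; one six-membered non-aromatic ring with 1 hetero atom) in place of a group of 3 heavy atoms (3 carbon; one three-membered non-aromatic ring of carbon only), on an amide-type nitrogen, the same change as from compound 1 to compound 2, at the same place. Since that earlier step was an at least 1.1-fold lower number from compound 1 to compound 2 (0.07 log units; that floor lies within the scatter), a similarly small step is expected, a 1.1-fold lower number from compound 3 to compound 4 (0.06 log units; within the scatter), in this assay. Compound 4 is therefore estimated at 35000 nM, between 12000 nM and 100000 nM.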

Compound 4, half-maximal inhibitory concentration: 27700 nM
Compound 4: middle estimate off by 1.3-fold (0.10 log units), on the high side; the measured number falls inside the stated range.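

In this assay, putting the larger amide group on the second core gives a 1.4-fold lower number from compound 3 to compound 4 (0.16 log units; within the scatter), a step that does not stand out from the usual scatter, and the two cases set side by side read: the same change on two cores in this assay, an at least 1.1-fold lower number (0.07 log units; that floor lies within the scatter) from compound 1 to compound 2 and a 1.4-fold lower number (0.16 log units; within the scatter) from compound 3 to compound 4; the limit leaves it open whether they differ. The swap to 1-methyl-1H-pyrazol-4-yl also carries over to the compounds with the larger amide group, giving a 3.0-fold lower number from compound 2 to compound 4 (0.48 log units; beyond the scatter), and its two cases read: the same change on two cores in this assay, an at least 2.5-fold lower number (0.39 log units; beyond the scatter) from compound 1 to compound 3 and a 3.0-fold lower number (0.48 log units; beyond the scatter) from compound 2 to compound 4; the limit leaves it open whether they differ. Both comparisons rest on compound 1, whose > 100000 nM is a limit and not a number, so the two changes look transferable between cores, but how closely their sizes match is not shown.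

Still open, on these data alone, is how a longer carbon chain or an amine would behave on the amide nitrogen. Also open, as far as these compounds go, is what a carboxylic acid would do in place of 1-methyl-1H-pyrazol-4-yl.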